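Swapping the methoxy arm for a thiophenyl sulfide

This account rests on a few compounds, and the source may have more. Where it says the series, first, only, none or still open, it means among the compounds named here.

Measured compounds in a physicochemical assay for lipophilicity, read by HPLC, measured as octanol-water partition; a lower number here means a more polar compound, a higher number a more lipophilic compound:
- compound 1 `O=C1O[C@@H](CN2CCCCC2)CN1c1ccc(-n2cc(-c3ccccn3)cn2)c(F)c1`: 3.1
- compound 2 `O=C1CCC(=O)N1C[C@H]1CN(c2ccc(-n3cc(-c4ccccn4)cn3)c(F)c2)C(=O)O1`: 1.58
- compound 3 `COC[C@H]1CN(c2ccc(-n3cc(-c4ccccn4)cn3)c(F)c2)C(=O)O1`: 2.18

Compound 3 stands second highest of the three. Its nearest neighbour is compound 2 a number 0.60 log units higher from compound 2 to compound 3 (beyond the scatter), and its furthest is compound 1 a number 0.92 log units lower from compound 1 to compound 3 (beyond the scatter); both steps lie beyond the scatter, so the arm on the saturated chain carbon bound to a saturated ring carbon clearly moves this read-out.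

Compound 4 `O=C1O[C@@H](CSc2cccs2)CN1c1ccc(-n2cc(-c3ccccn3)cn2)c(F)c1` differs from compound 3 in one place: (thiophen-2-yl)sulfanyl in place of methoxy on a saturated chain carbon bound to a saturated ring carbon. For the measured compounds named here, no measured step replaces methoxy with a sulfur-linked aromatic ring, so none bears on this change directly. What the measured steps do show is the range available at this position, from the large drop a number 1.52 log units lower from compound 1 to compound 2 (beyond the scatter) to the modest rise a number 0.60 log units higher from compound 2 to compound 3 (beyond the scatter). A group that enters with six heavy atoms and an aromatic ring in place of two heavy atoms is expected to push the number upward by a large step, a number 1.72 log units higher from compound 3 to compound 4 (beyond the scatter). For compound 4 the estimate is 3.9, within 3.3 to 4.5.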

Compound 4, partition coefficient: 4.29
Estimate against measurement, compound 4: 0.39 log units below; low and high end bracket the measured number.
By their numbers in this assay, from the lowest: compound 2; then compound 3; then compound 1; then compound 4.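

In this assay, the (thiophen-2-yl)sulfanyl arm produces a large rise over the methoxy arm, a number 2.11 log units higher from compound 3 to compound 4 (beyond the scatter), and an even larger one over the 2,5-dioxopyrrolidin-1-yl arm, a number 2.71 log units higher from compound 2 to compound 4 (beyond the scatter). It also passes the piperidin-1-yl arm, the highest of the earlier arms, a number 1.19 log units higher from compound 1 to compound 4 (beyond the scatter), so this position can carry the number well beyond the range the first three compounds set. Nothing measured here explains why this arm stands highest.

The compounds shown leave open how the rise divides between the sulfur link and the thiophene ring; a thiophen-2-yloxy arm, with oxygen as the link, would help separate the two. Also open, as far as these compounds go, is where a carboxylic acid or a longer alkyl chain would fall at this position.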